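Dihydroxyphenyl for chlorophenyl on a bis-benzylidene cyclohexanone

This account rests on a few compounds, and the source may have more. Where it says the series, first, only, none or still open, it means among the compounds named here.

Measured compounds:
compound 1, `COc1cccc(/C=C2\CCC/C(=C\c3ccc(Cl)c(Cl)c3)C2=O)c1OC`, 10800 nM
compound 2, `COc1ccc(/C=C2\CCC/C(=C\c3ccc(Cl)cc3)C2=O)cc1OC`, 4800 nM

In a functional assay on HT-1080 cells (Homo sapiens) for cytotoxicity, read by MTT assay, with a stated time of 72 h (on this read-out lower numbers stand for stronger inhibition and higher numbers for weaker inhibition), compound 2 gives 4800 nM, the lowest of the two numbers; compound 1 gives 10800 nM, a gap that lies beyond the scatter. Compound 3, `COc1ccc(/C=C2\CCC/C(=C\c3ccc(O)c(O)c3)C2=O)cc1OC`, is not yet measured. It differs from compound 2 in one place: 3,4-dihydroxyphenyl in place of 4-chlorophenyl on a double-bonded chain carbon bound to a double-bonded ring carbon. Going by the values given here, no measured pair shows this change, so the step is an expectation only. The step of a 1.7-fold higher number from compound 2 to compound 3 (0.22 log units; within the scatter) is expected to be small and toward weaker inhibition, near the scatter. Compound 3 is estimated at 8000 nM, within 2500 nM to 25000 nM.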

Compound 3, half-maximal inhibitory concentration: 4200 nM
Estimate against measurement, compound 3: 1.9-fold (0.28 log units) above, and the stated range covers the measured number.
By their numbers in this assay, from the lowest: compounds 3 and 2 (each within the scatter of the next); then compound 1.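

In this assay, 3,4-dihydroxyphenyl in place of 4-chlorophenyl on a double-bonded chain carbon bound to a double-bonded ring carbon gives a 1.1-fold lower number from compound 2 to compound 3 (0.06 log units; within the scatter) on the shared core. Going by these compounds alone, this is the first one-place comparison here, and it shows that a ring with two hydrogen-bond donors and a ring with chlorine and none give readings that cannot be told apart. No measurement shown explains this outcome. As far as these compounds go, whether an amine, a carboxylic acid or a longer chain at this place would give a different reading remains open.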